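A few compounds are considered here, and "the series" means these few. Any claim that something is new, unique, unknown or untested is made for them only; others in the source may bear on it.

Measured so far: compound 1 `CCC[C@@H]1O[C@H](COCc2ccccc2)[C@@H](OCc2ccccc2)[C@H](OCc2ccccc2)[C@H]1O`, 18900 nM; compound 2 `CC(C)C[C@@H]1O[C@H](COCc2ccccc2)[C@@H](OCc2ccccc2)[C@H](OCc2ccccc2)[C@H]1O`, > 50000 nM.

In a functional assay on HeLa cells (Homo sapiens) for antiproliferative activity, read by sulforhodamine B assay (a lower number here means a stronger inhibitor of growth, a higher number a weaker inhibitor of growth), compound 1 gives 18900 nM. Compound 2 reaches only the assay limit, > 50000 nM, so its position is known no closer than the limit of > 50000 nM in this assay, at which 1 of the 2 values shown sits. Among the measured compounds shown here, the one measured step, an at least 2.6-fold higher number from compound 1 to compound 2 (0.42 log units; beyond the scatter), is the sole evidence for the branch.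

Compound 3 `C=CC[C@@H]1O[C@H](COCc2ccccc2)[C@@H](OCc2ccccc2)[C@H](OCc2ccccc2)[C@H]1O` differs from compound 2 by vinyl in place of isopropyl on a saturated chain carbon bound to a saturated ring carbon. This removes the branch penalised in an at least 2.6-fold higher number from compound 1 to compound 2 (0.42 log units; beyond the scatter) and restores an unbranched chain as in compound 1. Compound 3 is therefore expected to land close to compound 1. For compound 3 the expected step is an at least 2.5-fold lower number from compound 2 to compound 3 (0.39 log units; beyond the scatter). The estimate for compound 3 is 20000 nM, ranging from 8000 nM to 50000 nM.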

Compound 3, concentration for 50% growth inhibition: 26200 nM
Beside the measured number, compound 3's estimate is 1.3-fold (0.12 log units) below it; the measured number falls inside the stated range.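

In this assay, vinyl in place of ethyl on a saturated chain carbon bound to a saturated ring carbon gives a 1.4-fold higher number from compound 1 to compound 3 (0.14 log units; within the scatter), so the double bond in the unbranched chain makes no readable difference. Vinyl in place of isopropyl at the same place gives an at least 1.9-fold lower number from compound 2 to compound 3 (0.28 log units; that floor lies within the scatter), so this step alone does not firmly confirm the loss seen with the branch. The figure for compound 2 is a limit and not a number: the limit of > 50000 nM in this assay, at which 1 of the 3 values shown sits.

Going by these compounds, whether a longer chain, an amine or a carboxylic acid at this place would shift growth inhibition remains open. Among the compounds shown here, with compound 2 the only branched member, it is also open whether other branched chains behave the same way.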